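Phenyl to Methyl on the Saturated Ring: Expected Lipophilicity

A few compounds are considered here, and "the series" means these few. Any claim that something is new, unique, unknown or untested is made for them only; others in the source may bear on it.

Compound 1 `CCOC(=O)C1C(=O)C=C(Nc2cccc(N3CCN(C)CC3)c2)CC1C` gives 3.05 in a physicochemical assay for lipophilicity; a higher number here means a more lipophilic compound, a lower number a more polar compound.
Compound 2 `CCN1CCN(c2ccc(NC3=CC(=O)C(C(=O)OC)C(c4ccccc4)C3)cc2)CC1` gives 4.39 in this assay.
Compound 3 `CCOC(=O)C1C(=O)C=C(Nc2cccc(N3CCN(C)CC3)c2)CC1c1ccccc1` gives 4.37 in this assay.

Compounds 3 and 1 share a core and differ in one place: methyl in place of phenyl on a saturated ring carbon. This change made a number 1.32 log units lower from compound 3 to compound 1 (beyond the scatter). Compound 2 has the same atoms as compound 3 joined differently; the difference between the two cores is not broken down here, and the values of compound 2 and compound 3 lie within the scatter of each other. Compound 4 `CCN1CCN(c2ccc(NC3=CC(=O)C(C(=O)OC)C(C)C3)cc2)CC1` has not yet been measured. It differs from compound 2 in the same kind of way: methyl in place of phenyl on a saturated ring carbon. Around the place, the ring atom next to it bears a methoxycarbonyl group in compound 2 where compound 3 has an ethoxycarbonyl group. The step is expected to be a number 1.32 log units lower from compound 2 to compound 4 (beyond the scatter), resting on the earlier a number 1.32 log units lower from compound 3 to compound 1 (beyond the scatter). Compound 4 is therefore estimated at 3.07, between 2.7 and 3.45.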

Compound 4, partition coefficient: 3.07
Compound 4: the middle estimate sits on the measured number at the digits printed; low and high end bracket the measured number.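

In this assay, methyl in place of phenyl on a saturated ring carbon gave a number 1.32 log units lower from compound 2 to compound 4 (beyond the scatter), a step of the same printed size as a number 1.32 log units lower from compound 3 to compound 1 (beyond the scatter), so in these two pairs the change carried over from one core to the other. For the compounds shown here, this is only two pairs, however, and it does not show that the step would hold across the whole series. Nothing measured here explains why the step has this size.

The compounds shown leave open how a longer chain such as propyl, or an amine, would compare with methyl and phenyl on that saturated ring carbon. They also leave open whether the step keeps its size on a third core.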